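Nitro for Trifluoromethyl on the Benzamide of Compound 2

The compounds below may be only part of what the source reports. "The series", "measured", "known", "first", "only" and "open" are said of these compounds alone.

The measured compounds:
compound 1, `COc1ccccc1C(=O)Nc1cccc(-c2oc3cc(-c4ccc(F)cc4)ccc3c(=O)c2O)c1`, gives 6370 nM in a functional assay on GTL 16 cells for antiproliferative activity against GTL 16 cell line (Homo sapiens), read by CCK-8 assay, with a stated time of 72 h; on this read-out higher numbers stand for weaker inhibition and lower numbers for stronger inhibition;
compound 2, `O=C(Nc1cccc(-c2oc3cc(-c4ccc(F)cc4)ccc3c(=O)c2O)c1)c1ccc(C(F)(F)F)cc1`, gives 33000 nM in this assay;
compound 3, `COc1cccc(C(=O)Nc2cccc(-c3oc4cc(-c5ccc(F)cc5)ccc4c(=O)c3O)c2)c1`, gives 12500 nM in this assay.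

All three share one core and differ only in the aryl group on the amide carbonyl. Compound 2 stands at the highest number of the three: a 2.6-fold lower number from compound 2 to compound 3 (0.42 log units; beyond the scatter), and in the other direction a 5.2-fold higher number from compound 1 to compound 2 (0.71 log units; beyond the scatter). Compounds 1 and 3 sit close together, a 2.0-fold higher number from compound 1 to compound 3 (0.29 log units; within the scatter).

Compound 4, `O=C(Nc1cccc(-c2oc3cc(-c4ccc(F)cc4)ccc3c(=O)c2O)c1)c1ccc([N+](=O)[O-])cc1`, is not yet measured. It differs from compound 2 in one place: nitro in place of trifluoromethyl on an aromatic carbon. Within the data shown here, no measured step touches this group on its own; the two steps that leave compound 2 replace the whole 4-(trifluoromethyl)phenyl with a methoxyphenyl, and both are modest moves to lower numbers. Among the measured compounds shown here, the change to nitro keeps the same ring and the same aromatic carbon, and nothing among the measured compounds points to a move in either direction. The expectation is therefore a step within the scatter, a 1.3-fold lower number from compound 2 to compound 4 (0.12 log units; within the scatter). For the measured compounds named here, no measured step covers this exact replacement, and the range is set wide. Compound 4 is estimated at 25000 nM, between 8000 nM and 80000 nM.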

Compound 4, half-maximal inhibitory concentration: 18200 nM
Compound 4: middle estimate off by 1.4-fold (0.14 log units), on the high side, and the stated range covers the measured number.
By their numbers in this assay, from the lowest: compounds 1, 3, 4 and 2 (each within the scatter of the next, the first and the last beyond it).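

In this assay, among these compounds, the step of a 1.8-fold lower number from compound 2 to compound 4 (0.26 log units; within the scatter) is the first one that keeps the phenyl ring and replaces only the group on this aromatic carbon, and it stays within the scatter, so trifluoromethyl and nitro cannot be told apart here. The step of a 1.5-fold higher number from compound 3 to compound 4 (0.16 log units; within the scatter) also lies within the scatter, while the step of a 2.9-fold higher number from compound 1 to compound 4 (0.46 log units; beyond the scatter) lies beyond it, so the modest gap that separated compound 2 from compound 1 is still there with 4-nitrophenyl in place of 4-(trifluoromethyl)phenyl. Nothing measured among these compounds bears on why the numbers fall as they do.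

The compounds shown do not settle whether the gap to compound 1 follows the identity of the group or its place on the ring, since the methoxy compounds differ from compound 2 and compound 4 in both at once. Also open, on these data alone, is what an amine, a carboxylic acid or a nitrile on this same aromatic carbon would give, and whether any of them would move the number beyond the scatter from compound 2.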